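Swapping the aryl group on a piperazine in a cytotoxicity series

This account rests on a few compounds, and the source may have more. Where it says the series, first, only, none or still open, it means among the compounds named here.

Three compounds share one core and differ only in the aryl group on an amine nitrogen in a ring. In a functional assay on MCF7 cells (Homo sapiens) for cytotoxicity, read by MTT assay, with a stated time of 24 h (on this read-out higher numbers stand for weaker inhibition and lower numbers for stronger inhibition), compound 1 `COc1ccccc1N1CCN(CC(=O)N2CCN(c3nnc(-c4ccccc4)c(-c4ccccc4)n3)CC2)CC1` gives 167000 nM. For compound 2 `COc1cccc(N2CCN(CC(=O)N3CCN(c4nnc(-c5ccccc5)c(-c5ccccc5)n4)CC3)CC2)c1` this assay reports only a limit, > 910000 nM. Compound 3 `O=C(CN1CCN(c2cccc(Cl)c2)CC1)N1CCN(c2nnc(-c3ccccc3)c(-c3ccccc3)n2)CC1` gives 56300 nM in this assay, the lowest of the two numbers shown, with compound 1 as its nearest neighbour. Every step among them lies beyond the scatter: an at least 5.4-fold higher number from compound 1 to compound 2 (0.73 log units; beyond the scatter); a 3.0-fold lower number from compound 1 to compound 3 (0.47 log units; beyond the scatter); an at least 16-fold lower number from compound 2 to compound 3 (1.20 log units; beyond the scatter). Compound 4 `O=C(CN1CCN(c2ccc([N+](=O)[O-])cc2)CC1)N1CCN(c2nnc(-c3ccccc3)c(-c3ccccc3)n2)CC1` has not yet been measured in this assay. It differs from compound 3 in one place: 4-nitrophenyl in place of 3-chlorophenyl on an amine nitrogen in a ring. Within the data shown here, the steps that bear on this change are those ending at compound 3, where the 3-chlorophenyl gave the lowest number, as in an at least 16-fold lower number from compound 2 to compound 3 (1.20 log units; beyond the scatter). Among the measured compounds shown here, no measured step tests a nitrophenyl group, so the direction rests on that chlorophenyl being the best of the three. A modest rise in this assay is therefore expected, a 2.1-fold higher number from compound 3 to compound 4 (0.33 log units; beyond the scatter). The estimate for compound 4 is 120000 nM, with a range from 40000 nM to 400000 nM.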

Compound 4, half-maximal inhibitory concentration: > 886000 nM
Compound 4: a limit, no number; the forecaster's own chance of this, stated with the estimate: 20%; at least 7.3-fold (0.86 log units) between middle value and limit.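

Compound 4 gives a limit and not a number: the limit of > 886000 nM in this assay, at which 1 of the 4 values shown sits. Replacing the aryl group on this amine nitrogen can therefore carry a large penalty in this assay, with an at least 15-fold higher number from compound 3 to compound 4 (1.19 log units; beyond the scatter), and the change also compares poorly with the 2-methoxyphenyl group, with an at least 5.3-fold higher number from compound 1 to compound 4 (0.72 log units; beyond the scatter). The 4-nitrophenyl group is now the second aryl group here, after the 3-methoxyphenyl group of compound 2, to end at a limit, so the step between those two compounds cannot be read.

Only compound 1 and compound 3 give numbers, so the series does not separate the nitro group itself from where it sits on the phenyl ring. A 3-nitrophenyl or a 4-chlorophenyl group on the same nitrogen would pull those two apart.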